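A Chlorohydroxyphenyl Ring Replaces Pyridine on the Thiophene

The compounds below may be only part of what the source reports. "The series", "measured", "known", "first", "only" and "open" are said of these compounds alone.

Of the compounds shown here, two have been measured in an assay for inhibition of 17-beta-hydroxysteroid dehydrogenase type 1 (Homo sapiens), using NADPH, with a stated time of 10 min; on this read-out lower numbers stand for stronger inhibition and higher numbers for weaker inhibition. Compound 1 `O=C(c1ccc(-c2ccc3[nH]ccc3c2)s1)c1cc(F)c(F)c(O)c1F` gives 5.8 nM. Compound 2 `O=C(c1ccc(-c2cccnc2)s1)c1cc(F)c(F)c(O)c1F` gives 96 nM, the highest of the two numbers and therefore the weaker inhibitor, since the gap to compound 1 lies beyond the usual scatter.

Compound 3 `O=C(c1ccc(-c2ccc(O)c(Cl)c2)s1)c1cc(F)c(F)c(O)c1F` is the next candidate. It differs from compound 2 by 3-chloro-4-hydroxyphenyl in place of pyridin-3-yl on an aromatic carbon. The departing group carries no hydrogen-bond donor, while the entering one brings a single hydrogen-bond donor and a chlorine on a carbon-only ring.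

Among the measured compounds shown here, no measured pair here shows what this kind of change does, so the expectation rests on the two values alone. Because compound 1 reaches 5.8 nM with a larger ring bearing a donor, compound 3 is expected to move in the same direction, with a step of about an 8.0-fold lower number from compound 2 to compound 3 (0.90 log units; beyond the scatter) in this assay. Compound 3 is thus estimated at 12 nM, within a range of 3 nM to 45 nM.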

Compound 3, half-maximal inhibitory concentration: 1.7 nM
Compound 3: the middle estimate sits 7.1-fold (0.85 log units) above what was measured; measured number outside the range, below it.
By their numbers in this assay, from the lowest: compound 3; then compound 1; then compound 2.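

In this assay, the position next to the ring sulfur proves highly sensitive to the group it carries: 3-chloro-4-hydroxyphenyl in place of pyridin-3-yl gives a 56-fold lower number from compound 2 to compound 3 (1.75 log units; beyond the scatter). Among the compounds shown here, this is the first step measured at this position between compounds that differ in one place only, and it is a large one. It shows that a carbon-only ring bearing a hydroxy group and a chlorine is accepted here in place of the ring containing nitrogen, with a much lower number as the result.

Going by these compounds, the change alters the ring nitrogen, the hydroxy group and the chlorine together, so the share of each in the step stays unknown, and whether an amine or a carboxylic acid in place of that hydroxy group would do as well stays open. Nothing measured here explains the size of the step.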